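Methylating the ring nitrogen on a longer-chain purine

A few compounds are considered here, and "the series" means these few. Any claim that something is new, unique, unknown or untested is made for them only; others in the source may bear on it.

Compound 1 `CCCCCC(CCO)n1cnc2c(NC)ncnc21` carries a methylamino group on its core and a side chain ending in a hydroxyl. In a functional assay on SW480 cells (Homo sapiens) for antiproliferative activity, read by MTT assay, with a stated time of 48 h (on this read-out higher numbers stand for weaker inhibition and lower numbers for stronger inhibition), compound 1 gives > 50000 nM, which is a limit of the assay rather than a number. Compound 2 `CCCCCC(CCO)n1cnc2c(N(C)C)ncnc21` differs from compound 1 by methyl in place of hydrogen on a nitrogen on an aromatic ring. In this assay compound 2 gives > 50000 nM, again a limit and not a number. The step that the two limits leave unreadable from compound 1 to compound 2 is therefore unreadable because both values sit at the limit of > 50000 nM in this assay, at which 2 of the 3 values shown sit. Compound 3 `CCCCCCCCCCC(CCO)n1cnc2c(NC)ncnc21` differs from compound 1 by pentyl in place of hydrogen on a saturated chain carbon, six bonds along the chain from an aromatic nitrogen. In this assay, going by the values given here, compound 3 gives 12000 nM, the only true number among the three measured compounds, and the step of an at least 4.1-fold lower number from compound 1 to compound 3 (0.61 log units; beyond the scatter) is at least modest.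

Compound 4 `CCCCCCCCCCC(CCO)n1cnc2c(N(C)C)ncnc21` has not yet been measured. It differs from compound 3 by methyl in place of hydrogen on a nitrogen on an aromatic ring, the same change that turns compound 1 into compound 2, on a nitrogen in the same surroundings. This change occurs twice among these compounds, yet its only measured instance gives no readable size. The expected step of a 1.3-fold higher number from compound 3 to compound 4 (0.10 log units; within the scatter) in this assay rests on compound 3 at 12000 nM and on the fact that the same change elsewhere left no readable mark, so little movement is assumed. Compound 4 is thus estimated at 15000 nM, with a likely range from 5000 nM to 50000 nM.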

Compound 4, half-maximal inhibitory concentration: 3320 nM
Compound 4: middle estimate off by 4.5-fold (0.65 log units), on the high side, and the stated range ends above it.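

In this assay, the pentyl change can now be followed with the dimethylamino group in place as well, where it gives an at least 15-fold lower number from compound 2 to compound 4 (1.17 log units; beyond the scatter), so it lowers the number on both the methylamino and the dimethylamino cores. Set side by side, the two steps point the same way, but their sizes cannot be compared: the same change on two cores in this assay, an at least 4.1-fold lower number (0.61 log units; beyond the scatter) from compound 1 to compound 3 and an at least 15-fold lower number (1.17 log units; beyond the scatter) from compound 2 to compound 4; the limit leaves it open whether they differ. Methylamino to dimethylamino gives a 3.6-fold lower number from compound 3 to compound 4 (0.56 log units; beyond the scatter) on the longer chain, but the same change from compound 1 to compound 2 cannot be read, so these compounds do not show that this step carries over to the shorter chain, where both values are limits of the assay and not numbers: the limit of > 50000 nM in this assay, at which 2 of the 4 values shown sit.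

Going by these compounds, it remains open whether a longer chain still would lower the number further, and whether the methyl step would keep its size on such a chain. The compounds shown also leave open what an amine or a carboxylic acid would do in place of the hydroxyl at the end of the side chain in this assay.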